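A few compounds are considered here, and "the series" means these few. Any claim that something is new, unique, unknown or untested is made for them only; others in the source may bear on it.

Measured in a functional assay on L1210 cells (Mus musculus) for antiproliferative activity, read by cell counting, with a stated time of 2 days; on this read-out higher numbers stand for weaker inhibition and lower numbers for stronger inhibition:
- compound 1 `COc1ccc(Nc2nc(N)c(C(=O)c3ccccc3)s2)cc1`: 850 nM
- compound 2 `Nc1nc(Nc2ccc(Cl)cc2)sc1C(=O)c1ccccc1`: > 10000 nM (a limit of the assay, not a number)
- compound 3 `COc1ccc(Nc2nc(N)c(C(=O)c3cc(OC)c(OC)c(OC)c3)s2)cc1`: 1500 nM

In this assay, among the measured compounds shown here, compound 1 at 850 nM and compound 3 at 1500 nM lie within the scatter of each other, and these are the only two true numbers in the set. Compound 2 stands at the limit of > 10000 nM in this assay, at which 1 of the 3 values shown sits.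

Compound 4 `COc1ccc(Nc2nc(N)c(C(=O)c3ccc([N+](=O)[O-])cc3)s2)cc1` is the next entry. It carries nitro in place of hydrogen on an aromatic carbon of a six-membered aromatic ring of carbon only, para to a large group (nitro in place of hydrogen on an aromatic carbon).

For the measured compounds named here, the one measured step, an at least 11-fold higher number from compound 1 to compound 2 (1.07 log units; beyond the scatter), is large and beyond the scatter. It replaces a different group at a different place, however, so it shows that a single substitution can cost much in this series but does not set the size for nitro. Going by the values given here, no measured step covers this change directly. A modest rise in the number is therefore expected in this assay, possibly not beyond the scatter, with a larger loss left open by the step to compound 2 at > 10000 nM.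

The expected change is a 1.8-fold higher number from compound 1 to compound 4 (0.25 log units; within the scatter). For compound 4 the estimate is 1500 nM, with an expected range from 350 nM to 7000 nM.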

Compound 4, half-maximal inhibitory concentration: 280 nM
For compound 4 the middle estimate is 5.4-fold (0.73 log units) above the measured one, outside the stated range (below it).
By their numbers in this assay, from the lowest: compound 4; then compounds 1 and 3 (each within the scatter of the next). At a limit, above all of these: compound 2.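

In this assay, nitro in place of hydrogen on an aromatic carbon of a six-membered aromatic ring of carbon only, para to a large group, gives a 3.0-fold lower number from compound 1 to compound 4 (0.48 log units; beyond the scatter), so this position tolerates a substituent larger than hydrogen and the number moves down rather than up. Among the compounds shown here, the only earlier step between compounds differing in one place, an at least 11-fold higher number from compound 1 to compound 2 (1.07 log units; beyond the scatter), ran the other way at a different place, so compound 4 shows that a single change on the shared core can also lower the number beyond the scatter. Nothing measured in this set gives a cause for the lower number.

From the compounds shown here alone, whether the drop belongs to nitro itself or would follow from other groups at this carbon stays open, and a nitrile, a carboxylic acid or an amine on the same carbon would separate these two readings. Also open, going by these compounds, is whether the lower number holds in a second cell line or read-out, since all of these values come from this assay alone.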